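This account rests on a few compounds, and the source may have more. Where it says the series, first, only, none or still open, it means among the compounds named here.

In an ADME assay on A549 cells (Homo sapiens) for cytotoxicity, read by resazurin assay, with a stated time of 48 h (a higher number here means that more compound is tolerated, a lower number that less compound is tolerated), compound 2 `COc1ccc(CNc2ccc(NC(=O)c3cc(Cl)ccc3O)c(Cl)c2)cc1` gives 80700 nM, and compound 1 `O=C(Nc1ccc(NCc2ccc(F)cc2)cc1Cl)c1cc(Cl)ccc1O` gives 54400 nM. Within the data shown here, these are the only two numbers so far. They lie within the scatter of each other, so neither compound can be ranked over the other. Compound 3 `O=C(Nc1ccc(NCc2cc(F)cc(Cl)c2)cc1Cl)c1cc(Cl)ccc1O` keeps the shared core and differs from compound 2 only in the group on a saturated chain carbon bound to a nitrogen on an aromatic ring: 3-chloro-5-fluorophenyl in place of 4-methoxyphenyl on a saturated chain carbon bound to a nitrogen on an aromatic ring. Among the measured compounds shown here, only one measured step bears on this change, and only in part: a 1.5-fold higher number from compound 1 to compound 2 (0.17 log units; within the scatter), where methoxy replaces fluoro on an aromatic carbon. For the measured compounds named here, that step stays within the scatter, but no measured compound carries the 3-chloro-5-fluorophenyl group, so the evidence is thin. Compound 3 loses the methoxy and carries fluoro, as compound 1 does at 54400 nM, so a slight lean towards that number is expected. The estimated step is a 1.6-fold lower number from compound 2 to compound 3 (0.21 log units; within the scatter), which would not go beyond the scatter. For compound 3 the estimated value is 50000 nM, with an expected range from 20000 nM to 120000 nM.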

Compound 3, half-maximal cytotoxic concentration: 11100 nM
For compound 3 the middle estimate is 4.5-fold (0.65 log units) above the measured one; the whole stated range lies above it.
By their numbers in this assay, from the lowest: compound 3; then compounds 1 and 2 (each within the scatter of the next).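

In this assay the aromatic ring on the saturated chain carbon bound to a nitrogen on an aromatic ring clearly matters: placing 3-chloro-5-fluorophenyl there gives a 7.3-fold lower number from compound 2 to compound 3 (0.86 log units; beyond the scatter) against the 4-methoxyphenyl compound and a 4.9-fold lower number from compound 1 to compound 3 (0.69 log units; beyond the scatter) against the 4-fluorophenyl compound. Compounds 1 and 2 lay within the scatter of each other and so showed no effect of changing the group on this ring, whereas both new steps lie beyond the scatter and show that the position can shift how much compound the cells tolerate, with compound 3 tolerated less than either earlier compound. No measurement shown here explains the drop.

The compounds shown do not separate the contributions of the two halogens, so it stays open whether a phenyl ring carrying chlorine alone or fluorine alone would behave like compound 3 or like compound 1. Also open, as far as these compounds go, is how the number would respond to a ring carrying an amine or a carboxylic acid at this position.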